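Amine nitrogen substituent and tolerated concentration in leukaemia cells

The source may report more compounds than this note shows. Statements on the series, on what has been measured and on what is new or still open speak of the compounds shown alone.

Compound 3 `Cc1cn([C@@H]2O[C@H](CO[Si](C)(C)C(C)(C)C)[C@@]3(OS(=O)(=O)C=C3NC(=O)c3ccccc3)[C@H]2O[Si](C)(C)C(C)(C)C)c(=O)n(C)c1=O` carries benzoyl on the amine nitrogen and gives 4910 nM in a functional assay on CCRF-CEM cells (Homo sapiens); a higher number here means that more compound is tolerated, a lower number that less compound is tolerated. Compound 1 `CCOC(=O)NC(=O)NC1=CS(=O)(=O)O[C@@]12[C@@H](CO[Si](C)(C)C(C)(C)C)O[C@@H](n1cc(C)c(=O)n(C)c1=O)[C@@H]2O[Si](C)(C)C(C)(C)C` gives 3000 nM, so a 1.6-fold higher number from compound 1 to compound 3 (0.21 log units; within the scatter); the two numbers lie within the scatter of each other. Compound 2 `Cc1cn([C@@H]2O[C@H](CO[Si](C)(C)C(C)(C)C)[C@@]3(OS(=O)(=O)C=C3NCCC(=O)OCc3ccccc3)[C@H]2O[Si](C)(C)C(C)(C)C)c(=O)n(C)c1=O` reaches only a limit of this assay, > 250000 nM. Compound 4 `COC(=O)C(=O)CNC1=CS(=O)(=O)O[C@@]12[C@@H](CO[Si](C)(C)C(C)(C)C)O[C@@H](n1cc(C)c(=O)n(C)c1=O)[C@@H]2O[Si](C)(C)C(C)(C)C` differs from compound 3 in one place: ((methoxycarbonyl)carbonyl)methyl in place of benzoyl on an amine nitrogen. The step that bears on this is an at least 50-fold lower number from compound 2 to compound 3 (1.70 log units; beyond the scatter), which exchanged a carbon chain on the amine nitrogen for a carbonyl-bearing group; compound 4 returns a carbon chain to that nitrogen. For compound 4 a large rise is therefore expected: a 12-fold higher number from compound 3 to compound 4 (1.09 log units; beyond the scatter). Compound 4 is estimated at 60000 nM, within 8000 nM to 300000 nM, possibly again only a limit.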

Compound 4, half-maximal cytotoxic concentration: 5570 nM
The estimate for compound 4 lay 11-fold (1.03 log units) above the measured number, and the stated range ends above it.
By their numbers in this assay, from the lowest: compounds 1, 3 and 4 (each within the scatter of the next). At a limit, above all of these: compound 2.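

A carbon chain on the amine nitrogen is therefore not enough for a high number in this assay: with ((methoxycarbonyl)carbonyl)methyl there, the results are a 1.1-fold higher number from compound 3 to compound 4 (0.05 log units; within the scatter) and a 1.9-fold higher number from compound 1 to compound 4 (0.27 log units; within the scatter), both within the scatter. The two chains themselves part widely, an at least 44-fold lower number from compound 2 to compound 4 (1.65 log units; beyond the scatter), so the chain's outer part matters at this position. The value of compound 2 is a limit, not a number: the limit of > 250000 nM in this assay, at which 1 of the 4 values shown sits.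

Going by these compounds alone, compound 2 remains the only compound at that limit. Open, from the compounds shown here alone, is whether a plain ethyl chain, or a chain ending in a carboxylic acid or an amine, would fall with compound 2 or with compound 4.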